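This account rests on a few compounds, and the source may have more. Where it says the series, first, only, none or still open, it means among the compounds named here.

Among the compounds with values here, compound 1 `COc1cc(-c2cc(/C=C/C(=O)c3ccc(N)cc3)[nH]n2)cc(OC)c1OC` carries the lower of the two numbers so far, though only within the scatter of the other: in a functional assay on A498 cells (Homo sapiens) for cytotoxicity, read by sulforhodamine B assay, with a stated time of 48 h, tested at 100 uM (a higher number here means a weaker effect of the compound at the concentration tested, a lower number a stronger effect), compound 1 gives -96%. Compound 2 `COc1ccc(-c2cc(/C=C/C(=O)c3ccc(OC)c(OC)c3)[nH]n2)cc1` gives -90% in this assay, and the two values show no separation. Compound 3 `COc1cc(-c2cc(/C=C/C(=O)c3ccc(Cl)c(Cl)c3)[nH]n2)cc(OC)c1OC` awaits measurement. It differs from compound 1 by 3,4-dichlorophenyl in place of 4-aminophenyl on a carbonyl carbon. Within the data shown here, no measured step of this kind exists, and both measured values lie far toward the strong side, so the expected step is small toward a weaker effect, or none beyond the scatter: a number 11 percentage points higher from compound 1 to compound 3 (beyond the scatter). Compound 3 is expected at -85%, within -100% to -50%.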

Compound 3, a percentage reported as activity, at one concentration (the size of the read-out at that concentration, not a potency): -25%
The estimate for compound 3 lay 60 percentage points below the measured number; measured number above the stated range.
By their numbers in this assay, from the lowest: compounds 1 and 2 (each within the scatter of the next); then compound 3.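

On the carbonyl carbon the aryl group is not interchangeable: in this assay, 3,4-dichlorophenyl in place of 4-aminophenyl gives a number 71 percentage points higher from compound 1 to compound 3 (beyond the scatter) and so a much weaker effect at the concentration tested. Within the data shown here, the earlier compounds sat together at the strong end, so this is the first sign that the read-out responds to this position. No available data explain the step. Still open, on these data alone, is whether the chlorines or the loss of the amine drives the change. A plain phenyl or 4-chlorophenyl on the same carbon would separate the two.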